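Phenyl for Cyclopropyl on an Imidazole Bearing a Bicyclic Amine

A few compounds are considered here, and "the series" means these few. Any claim that something is new, unique, unknown or untested is made for them only; others in the source may bear on it.

Measured compounds:
compound 1 `C[C@@H]1[C@H]2C[C@@H](C[C@H]1NCc1[nH]cnc1C1CC1)C2(C)C`: 163000 nM
compound 2 `C[C@@H]1[C@H]2C[C@@H](C[C@H]1NCc1[nH]cnc1-c1ccccc1)C2(C)C`: 39700 nM
compound 3 `CCCc1nc(C2CC2)[nH]c1CN[C@@H]1C[C@@H]2C[C@H]([C@H]1C)C2(C)C`: 112000 nM

In an ADME assay on MDCK cells (Canis lupus familiaris) for cytotoxicity, read by MTT assay, with a stated time of 48 h (on this read-out lower numbers stand for higher toxicity in this test and higher numbers for lower toxicity in this test), compound 1 gives 163000 nM and compound 2 gives 39700 nM; the change phenyl in place of cyclopropyl on an aromatic carbon made a 4.1-fold lower number from compound 1 to compound 2 (0.61 log units; beyond the scatter). Compound 3 gives 112000 nM in this assay. How the core of compound 3 differs from that of compound 1 is not broken down here. Compound 4 `CCCc1nc(-c2ccccc2)[nH]c1CN[C@@H]1C[C@@H]2C[C@H]([C@H]1C)C2(C)C` carries the same kind of change, (phenyl in place of cyclopropyl on an aromatic carbon), though here the phenyl sits between two ring nitrogen atoms and two ring bonds from the ring atom that bears a propyl group, rather than next to the ring nitrogen. Beside the earlier step, compound 4 is expected to show a 4.0-fold lower number from compound 3 to compound 4 (0.60 log units; beyond the scatter) in this assay, resting on the single comparable step a 4.1-fold lower number from compound 1 to compound 2 (0.61 log units; beyond the scatter). Compound 4 is estimated at 28000 nM, between 10000 nM and 70000 nM.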

Compound 4, half-maximal cytotoxic concentration: 143000 nM
For compound 4 the middle estimate is 5.1-fold (0.71 log units) below the measured one; measured number outside the range, above it.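

In this assay, phenyl in place of cyclopropyl gave a 1.3-fold higher number from compound 3 to compound 4 (0.11 log units; within the scatter), so on this core the change leaves the read-out within the scatter. The earlier step therefore does not carry over, and the two cores respond differently to the same change: the same change on two cores in this assay, a 4.1-fold lower number (0.61 log units; beyond the scatter) from compound 1 to compound 2 and a 1.3-fold higher number (0.11 log units; within the scatter) from compound 3 to compound 4, 5.2-fold (0.72 log units) apart, beyond the scatter of two such steps. Going by these compounds alone, with only one pair on each core, this shows that the size of the step cannot be assumed from one core to the other, but not whether the propyl group or the site of the change accounts for the gap.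

The compounds shown leave open how a pyridine ring would behave at this site. They also leave open whether an ethyl group or a longer chain in place of the propyl group would shift the step.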